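Swapping the pyrrolidine for dimethylamino on compound 1

This account rests on a few compounds, and the source may have more. Where it says the series, first, only, none or still open, it means among the compounds named here.

Measured so far:
- compound 1, `Nc1noc2ccc(-n3nc(C(F)(F)F)c4c3C(=O)N(c3ccc(-c5ccccc5CN5CCCC5)cc3)CC4)cc12`: 37%
- compound 2, `Nc1noc2ccc(-n3nc(C(F)(F)F)c4c3C(=O)N(c3ccc(-c5ccccc5CN5CC[C@@H](O)C5)cc3F)CC4)cc12`: 81%

Going by the values given here, in an in vivo ADME assay on the whole organism for pharmacokinetics, with Canis familiaris (Canis lupus familiaris) as the target (a lower number here means that a smaller share of the oral dose reaches the circulation, a higher number that a larger share of the oral dose reaches the circulation), compound 1 gives 37%, the lowest of the two numbers known. Compound 2 gives 81%, a number beyond the scatter above it, but compound 2 differs from compound 1 in more than one place, so its value says nothing about any single change.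

Compound 3, `CN(C)Cc1ccccc1-c1ccc(N2CCc3c(C(F)(F)F)nn(-c4ccc5onc(N)c5c4)c3C2=O)cc1`, differs from compound 1 in one place: dimethylamino in place of pyrrolidin-1-yl on a saturated chain carbon bound to an aromatic carbon. The amine at that chain carbon stays, only the group on its nitrogen changes. Among the compounds with values here, no measured pair shows what such a change does in this assay. The step from compound 1 is therefore expected to be small, a number 3 percentage points higher from compound 1 to compound 3 (within the scatter), in no sure direction and possibly within the scatter. Compound 3 is expected to give 40%, within 20% to 65%.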

Compound 3, oral bioavailability: 50%
The estimate for compound 3 lay 10 percentage points below the measured number; the range from low to high includes it.
By their numbers in this assay, from the lowest: compound 1; then compound 3; then compound 2.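

In this assay, going by these compounds alone, exchanging pyrrolidin-1-yl for dimethylamino on the saturated chain carbon bound to an aromatic carbon gives a number 13 percentage points higher from compound 1 to compound 3 (beyond the scatter) and is the first change at this position that can be read on its own. It shows that this position is not indifferent to the group on the amine nitrogen: the entering group has fewer heavy atoms and no ring, while the hydrogen-bond donor and acceptor counts stay the same. Nothing measured here bears on why the number moved.

Going by these compounds, it remains open how a piperidin-1-yl or morpholin-4-yl group, or an unsubstituted amine, would behave at this chain carbon. On these data alone, it also remains open whether dimethylamino would produce a similar step on compound 2, which differs from compound 1 in more than one place.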